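The compounds below may be only part of what the source reports. "The series", "measured", "known", "first", "only" and "open" are said of these compounds alone.

Working notes on the series. The shared core of compound 1 `C=CC(=O)Nc1ccc(Cn2nc(-c3ccc(Oc4ccccc4)cc3)cc2C(=O)O)cc1` carries a carboxy group on an aromatic carbon, a phenoxyphenyl substituent and a benzyl group bearing an acrylamide. In a functional assay on Rec1 cells (Homo sapiens) for inhibition, read by luminescence and CellTiter-Glo, with a stated time of 72 h (on this read-out higher numbers stand for weaker inhibition and lower numbers for stronger inhibition), compound 1 gives > 60000 nM, which is a limit of the assay and not a number. Compound 3 `C=CC(=O)Nc1ccc(Cn2nc(-c3ccc(Oc4ccccc4)cc3)cc2CO)cc1` has hydroxymethyl in place of carboxy on an aromatic carbon, and in this assay compound 3 gives 3500 nM. The step is an at least 17-fold lower number from compound 1 to compound 3 (1.23 log units; beyond the scatter). Within the data shown here, compound 2 `C/C=C/C(=O)Nc1ccc(Cn2nc(-c3ccc(Oc4ccccc4)cc3)cc2C(=O)OCC)cc1`, an ethyl ester with a crotonamide, gives 13100 nM in this assay; no single-point step connects it to the others, so only its value is noted. Compound 1 therefore stands at the limit, (the limit of > 60000 nM in this assay, at which 1 of the 3 values shown sits), while compounds 2 and 3 return numbers.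

Compound 4 `C=CC(=O)Nc1cccc(Cn2nc(-c3ccc(Oc4ccccc4)cc3)cc2C(=O)O)c1` differs from compound 1 by 3-((vinylcarbonyl)amino)phenyl in place of 4-((vinylcarbonyl)amino)phenyl on a saturated chain carbon bound to an aromatic nitrogen. The carboxy group is kept. Among the measured compounds shown here, no measured step varies where the acrylamide sits on the benzyl ring; the only step with a number, an at least 17-fold lower number from compound 1 to compound 3 (1.23 log units; beyond the scatter), concerns the acid itself and does not bear on this change. For compound 4 the expectation is thus no step beyond the scatter, a number no higher from compound 1 to compound 4 (the limit leaves the size open), with compound 4 most likely again at the limit. Compound 4 is estimated at 60000 nM, within 20000 nM to 180000 nM.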

Compound 4, half-maximal inhibitory concentration: 33100 nM
Beside the measured number, compound 4's estimate is 1.8-fold (0.26 log units) above it, and the stated range covers the measured number.
By their numbers in this assay, from the lowest: compound 3; then compound 2; then compound 4. At a limit, above all of these: compound 1.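

Among these compounds, with the carboxy group kept, 3-((vinylcarbonyl)amino)phenyl in place of 4-((vinylcarbonyl)amino)phenyl on a saturated chain carbon bound to an aromatic nitrogen is the only measured change at this position, and it reads as an at least 1.8-fold lower number from compound 1 to compound 4 (0.25 log units; that floor lies within the scatter). Compound 1 remains a limit of the assay and not a number: the limit of > 60000 nM in this assay, at which 1 of the 4 values shown sits. In this assay compound 4 gives 33100 nM, so this change shows that a carboxy compound of the series can return a number. The true size of the step cannot be read, and its floor alone does not establish a difference between the two placements.

On these data alone, it remains open whether the same change would shift the hydroxymethyl compound 3 or the ethyl ester compound 2, where numbers on both sides could give the step a real size. Also open, as far as these compounds go, is what a propionamide or a plain amine in place of the acrylamide would give at either placement, which would show whether the acrylamide matters to the values seen here.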